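Substituting the Pyridine Ortho Group in a TRPV1 Antagonist Series

The source may report more compounds than this note shows. Statements on the series, on what has been measured and on what is new or still open speak of the compounds shown alone.

Three compounds of one amide series have been characterised in a functional assay for antagonist activity at transient receptor potential cation channel subfamily V member 1 (Homo sapiens), read by FLIPR; a higher number here means a weaker inhibitor, a lower number a stronger inhibitor. Compound 1 `O=C(Nc1ccccc1)c1ccc(-c2ncccc2C(F)(F)F)cc1` reaches only the limit of the assay, giving > 4000 nM, which is the limit marked by the limit of > 4000 nM in this assay, at which 1 of the 3 values shown sits. Compound 2 `Cc1cccnc1-c1ccc(C(=O)Nc2ccc(C(F)(F)F)cc2)cc1` gives 65 nM. Compound 3 `CC(C)(C)c1ccc(NC(=O)c2ccc(-c3ncccc3NC3CCCC3)cc2)cc1` gives 190 nM, the higher of the two numbers that were read; the gap between compound 2 and compound 3 is beyond the usual scatter, so compound 3 is the weaker inhibitor of the two. Compound 1 supplies only a limit and cannot be ranked against either.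

Compound 4 `Cc1nnc(-c2cccnc2-c2ccc(C(=O)Nc3ccc(C(C)(C)C)cc3)cc2)o1` has not yet been measured in this assay. It differs from compound 3 in one place: 5-methyl-1,3,4-oxadiazol-2-yl in place of cyclopentylamino on an aromatic carbon. Within the data shown here, no measured pair in this set isolates this change, so its effect is not known from the data. The step from compound 3 to compound 4 is expected to be modest, on the order of a 1.2-fold lower number from compound 3 to compound 4 (0.07 log units; within the scatter), with the direction uncertain. On that basis compound 4 is estimated to give 160 nM in this assay, within a range from 40 nM to 700 nM.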

Compound 4, half-maximal inhibitory concentration: 387 nM
Compound 4: the middle estimate sits 2.4-fold (0.38 log units) below what was measured; the range from low to high includes it.
By their numbers in this assay, from the lowest: compound 2; then compound 3; then compound 4. At a limit, above all of these: compound 1.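

At this carbon, ortho to a large group and two atoms from the ring nitrogen, exchanging cyclopentylamino for 5-methyl-1,3,4-oxadiazol-2-yl is the only change shown that can be read on its own, and in this assay it gives a 2.0-fold higher number from compound 3 to compound 4 (0.31 log units; beyond the scatter). The two groups have the same number of heavy atoms but differ in kind: one is a five-membered non-aromatic ring of carbon with 1 hydrogen-bond donor, the other a five-membered aromatic ring with 3 hetero atoms and 0 hydrogen-bond donors. The position therefore accepts both very different groups with only a modest loss, and nothing measured here explains that loss.

This single pair changes ring type, donor count and acceptor count together, so it leaves open which of these differences matters. A cyclopentyloxy group at this carbon would keep the carbon ring without the amine, while a 1,3,4-oxadiazol-2-yl group lacking the methyl would show whether that methyl contributes to the step.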